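The source may hold more compounds than are shown below. What is called first, only, known or untested is meant among the compounds shown, and "the series" means these compounds.

Of the compounds shown here, three have been measured in a functional assay on C6 cells (Rattus norvegicus) for cytotoxicity, read by MTT assay, with a stated time of 24 h, tested at 50 ug/mL; on this read-out lower numbers stand for a stronger effect and higher numbers for a weaker effect at the one concentration tested. Compound 1 `Cc1nnc(SCC(=O)N/N=c2/scc(-c3ccccc3)n2-c2ccccc2)s1` gives 63.9%, the highest of the three numbers, which on this read-out means the weakest effect among them. Compound 3 `Cn1cnnc1SCC(=O)N/N=c1/scc(-c2ccccc2)n1-c1ccccc1`, which carries a 4-methyl-4H-1,2,4-triazol-3-yl in place of the 5-methyl-1,3,4-thiadiazol-2-yl on the sulfur, gives 62.4%, and the step of a number 1.5 percentage points lower from compound 1 to compound 3 (within the scatter) lies within the scatter. Compound 2 `Cn1nnnc1SCC(=O)N/N=c1/scc(-c2ccc(C#N)cc2)n1-c1ccccc1` differs from compound 1 in two places. Compound 2 gives 35.6%, a number well below that of compound 1 and beyond the scatter.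

Compound 4 `Cc1ccc(-c2cs/c(=N/NC(=O)CSc3nnc(C)s3)n2-c2ccccc2)cc1` differs from compound 1 in one place: methyl in place of hydrogen on an aromatic carbon, that is, phenyl becomes 4-methylphenyl. Going by the values given here, no measured step touches this ring; the only single-point step available, from compound 1 to compound 3, concerns the heteroaryl on the sulfur and was within the scatter, so it offers no guide on a methyl entering the phenyl. Without evidence of a change, compound 1 with its value of 63.9% is the anchor, and the expected step of a number 1.9 percentage points lower from compound 1 to compound 4 (within the scatter) is none beyond the scatter. Compound 4 is therefore estimated at 62%, in a range from 45% to 78% in this assay .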

Compound 4, a percentage reported as activity, at one concentration (the size of the read-out at that concentration, not a potency): 40.6%
For compound 4 the middle estimate is 21.4 percentage points above the measured one; the whole stated range lies above it.
By their numbers in this assay, from the lowest: compounds 2 and 4 (each within the scatter of the next); then compounds 3 and 1 (each within the scatter of the next).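

The change from phenyl to 4-methylphenyl is the first one shown at this ring, and in this assay it appears as a number 23.3 percentage points lower from compound 1 to compound 4 (beyond the scatter), so on this read-out the effect at the one concentration tested is stronger with the methyl in place. A single methyl, para to a large group, is thus enough for a step beyond the scatter, whereas the exchange of the heteroaryl on the sulfur, a number 1.5 percentage points lower from compound 1 to compound 3 (within the scatter), stayed within it. Nothing at hand bears on the reason for the methyl step.

Going by these compounds, it remains open whether this step is particular to methyl or would also appear with another group at the same place, such as an ethyl chain, a methoxy group, a chlorine atom or an amine. Going by these compounds alone, it is equally open whether the step would hold with the 4-methyl-4H-1,2,4-triazol-3-yl of compound 3 on the sulfur, as the one step at this ring rests on the 5-methyl-1,3,4-thiadiazol-2-yl alone.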